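The source may report more compounds than this note shows. Statements on the series, on what has been measured and on what is new or still open speak of the compounds shown alone.

Three compounds share one core, carrying a methyl ester and one or two benzoyl groups. Compound 1 `COC(=O)c1ccc2ccc(C(=O)c3ccccc3)c-2cc1` in an assay on cells for displacement of a labelled ligand from Orexin/Hypocretin receptor type 1 (Homo sapiens), read by scintillation counting, with stated times of 10 min and 90 min, tested at 10 uM (on this read-out lower numbers stand for less inhibition and higher numbers for more inhibition at the one concentration tested (going by the name of the read-out)), gives 7.2%. Compound 2 `COC(=O)c1ccc2c(C(=O)c3ccccc3)cc(C(=O)c3ccccc3)c-2cc1` gives -10.6% in this assay. Within the data shown here, the one measured step, a number 17.8 percentage points lower from compound 1 to compound 2 (beyond the scatter), came with a benzoyl in place of hydrogen on an aromatic carbon. Compound 3 `COC(=O)c1cccc2c(C(=O)c3ccccc3)cc(C(=O)c3ccc(C(F)(F)F)cc3)c-2c1` gives 10.4% in this assay; this is the highest of the three numbers, although its gap to compound 1 lies within the scatter, so those two cannot be ordered, while its gap to compound 2 lies beyond the scatter.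

Compound 4 `COC(=O)c1cccc2c(C(=O)c3ccccc3)cc(C(=O)c3ccc(C(Cl)(Cl)Cl)cc3)c-2c1` has not yet been measured. It differs from compound 3 by trichloromethyl in place of trifluoromethyl on an aromatic carbon. Among the measured compounds shown here, no measured step bears on this change: the single step, a number 17.8 percentage points lower from compound 1 to compound 2 (beyond the scatter), concerns a benzoyl entering in place of hydrogen, not the exchange of one group for another of the same kind, and nothing measured speaks for a larger or a smaller number. The expected step in this assay is therefore a number 0.4 percentage points lower from compound 3 to compound 4 (within the scatter), none beyond the scatter. Compound 4 is estimated at 10%, with a range from -6% to 26%.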

Compound 4, a percentage reported as inhibition, at one concentration (the size of the read-out at that concentration, not a potency): 10.4%
Compound 4: middle estimate off by 0.4 percentage points, on the low side, and the stated range covers the measured number.
By their numbers in this assay, from the lowest: compound 2; then compounds 1, 3 and 4 (each within the scatter of the next).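

In this assay, putting trichloromethyl in place of trifluoromethyl on the aromatic carbon para to a large group gives no change at the digits printed from compound 3 to compound 4 (within the scatter), so this exchange cannot be told apart from no effect at the one concentration tested. Among these compounds, the earlier compounds showed only what happened when a whole benzoyl group entered the molecule, whereas this pair is the first to show one group exchanged for another of the same kind at this place, and the read-out does not separate the 4-(trifluoromethyl)phenyl from the 4-(trichloromethyl)phenyl. Nothing available explains why these two groups read alike, and the pair on its own supports no wider rule about this position.

The compounds shown leave open whether a very different group at this same place, such as an amine, a carboxylic acid or a longer carbon chain, would give a number beyond the usual scatter. Among the compounds shown here, they also leave open whether the same exchange would read alike on another version of the shared core, since only this one pair speaks to it.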